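From fluoro to trifluoromethoxy in a growth-inhibition series

This account rests on a few compounds, and the source may have more. Where it says the series, first, only, none or still open, it means among the compounds named here.

Three compounds have numbers in a functional assay on KB cells (Homo sapiens) for inhibition, read by sulforhodamine B assay; a lower number here means a stronger inhibitor of growth, a higher number a weaker inhibitor of growth. Compound 1 (`Cc1ccc2[nH]c(-c3ccc(-c4ccc(-c5ccc(N(C)C)cc5)cc4)cc3)nc2c1`) gives 6240 nM, compound 2 (`COc1ccc(-c2ccc(-c3ccc(-c4nc5cc(C)ccc5[nH]4)cc3)cc2)cc1OC`) gives 2190 nM, and compound 3 (`Fc1ccc(-c2ccc(-c3ccc(-c4nc5ccccc5[nH]4)cc3)cc2)cc1`) gives 41300 nM. The last is the highest of the three numbers, which makes compound 3 the weakest growth inhibitor measured so far.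

Compound 4 (`FC(F)(F)Oc1ccc(-c2ccc(-c3ccc(-c4nc5ccccc5[nH]4)cc3)cc2)cc1`) has trifluoromethoxy in place of fluoro on an aromatic carbon, para to a large group: trifluoromethoxy in place of fluoro on an aromatic carbon.

Within the data shown here, only one measured step offers any guide: a 2.8-fold lower number from compound 1 to compound 2 (0.45 log units; beyond the scatter). It is a modest change from exchanging one substituent for another on an aromatic carbon. Among the measured compounds shown here, it does not start from compound 3, and no measurement yet tests the fluoro group directly, so it bears on this change only loosely. A step of similar modest size toward a lower number is therefore expected, though with wide uncertainty. The estimated change is a 2.3-fold lower number from compound 3 to compound 4 (0.36 log units; beyond the scatter) in this assay. For compound 4 the expected value is 18000 nM, with an estimated range from 5000 nM to 60000 nM.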

Compound 4, concentration for 50% growth inhibition: 39100 nM
Compound 4: middle estimate off by 2.2-fold (0.34 log units), on the low side, within the range that was stated.
By their numbers in this assay, from the lowest: compound 2; then compound 1; then compounds 4 and 3 (each within the scatter of the next).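

In this assay, replacing fluoro with trifluoromethoxy on an aromatic carbon para to a large group gives a 1.1-fold lower number from compound 3 to compound 4 (0.02 log units; within the scatter), so this exchange does not separate the two compounds. The earlier exchange of substituents, a 2.8-fold lower number from compound 1 to compound 2 (0.45 log units; beyond the scatter), lay beyond the scatter, whereas this larger group, which also brings a hydrogen-bond acceptor, leaves the reading within it. No measurement at hand explains this outcome.

The compounds shown leave open whether an amine, a carboxylic acid or a longer alkoxy chain at this position would move the number, and whether 4-(dimethylamino)phenyl or 3,4-dimethoxyphenyl would give the readings of compound 1 and compound 2 on the core of compound 3. They also leave open what the methyl group on the core of compound 1 and compound 2 contributes.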